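Substituent on the double-bonded nitrogen: three values and one estimate

The source may hold more compounds than are shown below. What is called first, only, known or untested is meant among the compounds shown, and "the series" means these compounds.

Values in a functional assay on the whole organism (blood, strain Wistar-Okamoto) with Rattus norvegicus as the target, with a stated time of 5 days (a lower number here means that less compound is needed, a higher number that more compound is needed for the effect), for the measured compounds:
compound 1, `CCC/N=C(\NC#N)Nc1cccnc1`: 20 mg/kg
compound 2, `N#CN/C(=N\C1CC1)Nc1cccnc1`: 20 mg/kg
compound 3, `N#CN/C(=N\C1CCCCC1)Nc1cccnc1`: 20 mg/kg

Compound 1 stands level with compounds 2 and 3 at the digits shown in this assay; the nearest is compound 2 and the furthest compound 3, yet neither gap reaches beyond the scatter. All three measured steps alter only the group on the double-bonded nitrogen: no change at the digits printed from compound 1 to compound 2 (within the scatter), no change at the digits printed from compound 1 to compound 3 (within the scatter) and no change at the digits printed from compound 2 to compound 3 (within the scatter). A propyl, a cyclopropyl and a cyclohexyl at that place thus give the same read-out within the scatter.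

Compound 4, `N#CN/C(=N\Cc1ccco1)Nc1cccnc1`, is not yet measured. Relative to compound 1 the change is furan-2-yl in place of ethyl on a saturated chain carbon bound to a double-bonded nitrogen. For the measured compounds named here, no measured step brings an aromatic ring into this place, so the bearing of the three steps is indirect: each varied the group on the double-bonded nitrogen and none moved the read-out. On that basis the expected step in this assay is no change at the digits printed from compound 1 to compound 4 (within the scatter), none beyond the scatter. Compound 4 is therefore estimated at 20 mg/kg, within 10 mg/kg to 40 mg/kg.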

Compound 4, minimum effective dose: 20 mg/kg
The estimate for compound 4 equals the measured number at the digits printed, within the range that was stated.
By their numbers in this assay, from the lowest: compounds 1, 2, 3 and 4 (each within the scatter of the next).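

In this assay the group on the double-bonded nitrogen can now also carry an aromatic ring: with furan-2-yl in place of ethyl on a saturated chain carbon bound to a double-bonded nitrogen, there is no change at the digits printed from compound 1 to compound 4 (within the scatter), although the change brings in one five-membered aromatic ring with 1 hetero atom and 1 hydrogen-bond acceptor. The comparisons with the two cycloalkyl groups read the same, with no change at the digits printed from compound 3 to compound 4 (within the scatter) and no change at the digits printed from compound 2 to compound 4 (within the scatter), so the flat read-out now spans chain, saturated ring and furan-bearing groups across these four compounds. No supporting data bear on this result.

Going by these compounds, it remains open whether an amine, a carboxylic acid or a longer chain at this place would also leave the read-out unmoved. With all four groups level, the compounds shown do not reveal which change at this place, if any, would move the minimum effective dose.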